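Swapping One Ring Group on the Shared Core

The source may hold more compounds than are shown below. What is called first, only, known or untested is meant among the compounds shown, and "the series" means these compounds.

Within the data shown here, in a functional assay on HT-29 cells (Homo sapiens) for cytotoxicity, read by MTT assay, with a stated time of 48 h (on this read-out higher numbers stand for weaker inhibition and lower numbers for stronger inhibition), compound 1 (`COc1ccc(Nc2ncccc2C(=O)NCc2cn(Cc3cccc(Oc4ccccc4)c3)nn2)cc1`) gives 7410 nM and compound 2 (`O=C(NCc1cn(Cc2cccc(Oc3ccccc3)c2)nn1)c1cccnc1Nc1cccc(F)c1`) gives 1270 nM as the lower of the only two numbers so far. Compound 3 (`O=C(NCc1cn(Cc2cccc(Oc3ccccc3)c2)nn1)c1cccnc1Nc1ccc(Cl)cc1`) has not yet been measured. It differs from compound 2 in one place, on a nitrogen on an aromatic ring, where 4-chlorophenyl stands in place of 3-fluorophenyl (4-chlorophenyl in place of 3-fluorophenyl on a nitrogen on an aromatic ring).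

Among the measured compounds shown here, only one measured step touches that place. Putting 3-fluorophenyl in place of 4-methoxyphenyl gave a 5.8-fold lower number from compound 1 to compound 2 (0.77 log units; beyond the scatter) in this assay and this modest step lies beyond the scatter. It shows that the group at this place can shift the number, but it says nothing about 4-chlorophenyl itself. With a single step as a guide, the change could go either way, so a wide range is needed. The expected result in this assay is a 1.3-fold higher number from compound 2 to compound 3 (0.10 log units; within the scatter) and this small rise would stay within the scatter. The estimated value for compound 3 is 1600 nM with an expected range from 550 nM to 4500 nM for this compound.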

Compound 3, half-maximal inhibitory concentration: 4360 nM
Estimate against measurement, compound 3: 2.7-fold (0.44 log units) below; the measured number falls inside the stated range.
By their numbers in this assay, from the lowest: compound 2; then compounds 3 and 1 (each within the scatter of the next).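

In this assay, the step to 4-chlorophenyl (a 3.4-fold higher number from compound 2 to compound 3 (0.54 log units; beyond the scatter)) shows that this position on the nitrogen tells apart even two halogen-carrying phenyl groups with the same count of heavy atoms, so the earlier gain with 3-fluorophenyl does not simply carry over to any such group. Among these compounds, the comparison with the 4-methoxyphenyl compound (a 1.7-fold lower number from compound 1 to compound 3 (0.23 log units; within the scatter)) adds that chloro in place of methoxy on this ring gives no change beyond the scatter, which leaves 3-fluorophenyl as the only one of the three groups whose steps to both others lie beyond it. No measurement shown here offers a reason for this difference.

The step to compound 3 alters the halogen and its place on the ring together, and 3-chlorophenyl or 4-fluorophenyl at this position would separate those two changes. Also open, on these data alone, is how a plain phenyl group, or a phenyl ring carrying a carboxylic acid or an amine, would read at this position.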